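The compounds below may be only part of what the source reports. "The series", "measured", "known", "first", "only" and "open" are said of these compounds alone.

Compound 1 `Cc1ccc(Cn2c(=O)[nH]c3c(N)nc(C(F)(F)F)cc32)nn1`: < 11 mL.min-1.g-1
Compound 2 `Cc1cccc(Cn2c(=O)[nH]c3c(N)nc(C(F)(F)F)cc32)n1`: 27 mL.min-1.g-1

In an in vitro ADME assay on microsomes from liver (Rattus norvegicus) for metabolic stability (a higher number here means faster removal of the compound, a lower number slower removal), compound 1 gives < 11 mL.min-1.g-1, which is a limit of the assay rather than a number (the limit of < 11 mL.min-1.g-1 in this assay, at which 1 of the 2 values shown sits). Compound 2 gives 27 mL.min-1.g-1. Going by the values given here, the only measured step is an at least 2.4-fold higher number from compound 1 to compound 2 (0.38 log units; beyond the scatter). Compound 3 `Nc1ccc(Cn2c(=O)[nH]c3c(N)nc(C(F)(F)F)cc32)cn1` differs from compound 1 by 6-aminopyridin-3-yl in place of 6-methylpyridazin-3-yl on a saturated chain carbon bound to an aromatic nitrogen. Among the compounds with values here, no measured step covers this change, so the direction cannot be read from the numbers; compound 1 stands at the limit, so only a higher number could be seen. Compound 3 is estimated at 10 mL.min-1.g-1, from 4 mL.min-1.g-1 to 25 mL.min-1.g-1, an expected step that the limit leaves unreadable from compound 1 to compound 3.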

Compound 3, intrinsic clearance in microsomes: < 10 mL.min-1.g-1
Compound 3: only a limit was reported (the forecaster's own chance of this, stated with the estimate: 55%); the middle value lies on the limit itself.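

In this assay, the step to 6-aminopyridin-3-yl on a saturated chain carbon bound to an aromatic nitrogen is an at least 2.7-fold lower number from compound 2 to compound 3 (0.43 log units; beyond the scatter), so 6-methylpyridin-2-yl now stands apart from two other groups at this place. Compound 3 gives only a limit of the assay, not a number: the limit of < 10 mL.min-1.g-1 in this assay, at which 1 of the 3 values shown sits. Compound 1 also gives only a limit, so the step between these two cannot be read: the limit of < 11 mL.min-1.g-1 in this assay, at which 1 of the 3 values shown sits. On these data alone, how far the true values lie under these limits stays open. As far as these compounds go, whether the amine itself matters also stays open; a plain pyridin-3-yl or a 6-methoxypyridin-3-yl at this place would address that.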